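Compound 3 and One Group Exchanged

The source may report more compounds than this note shows. Statements on the series, on what has been measured and on what is new or still open speak of the compounds shown alone.

Of the compounds shown here, three have been measured so far, and they sit close together. In an in vivo ADME assay on the whole organism (strain Sprague-Dawley) for metabolic stability, with Rattus norvegicus as the target, at a dose of 2 mg/kg by the intravenous route (a higher number here means that the compound lasts longer, a lower number that the compound disappears faster), compound 1 `N#Cc1cc(Cl)cc(Oc2cc(OCc3noc4nc(N)ccc34)ccc2Cl)c1` gives 5.8 h, compound 2 `N#Cc1cc(Cl)cc(Oc2cc(OCc3n[nH]c4ncccc34)cc(Cl)c2Cl)c1` gives 9.4 h and compound 3 `N#Cc1cc(Cl)cc(Oc2cc(OCc3n[nH]c4nc(N)ccc34)cc(F)c2Cl)c1` gives 4.6 h. Compound 3 lies within the scatter of compound 1, while the gap between compound 3 and compound 2 lies just beyond the scatter, with compound 2 holding the higher number. Compound 1 and compound 2 lie within the scatter of each other.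

Compound 4 `N#Cc1cc(Cl)cc(Oc2cc(OCc3noc4nc(N)ccc34)cc(F)c2Cl)c1` departs from compound 3 in one place, on a saturated chain carbon bound to an oxygen on an aromatic ring: a group of 10 heavy atoms (6 carbon, 3 nitrogen, 1 oxygen; one five-membered aromatic ring with 2 hetero atoms, one six-membered aromatic ring with 1 hetero atom) in place of a group of 10 heavy atoms (6 carbon, 4 nitrogen; one five-membered aromatic ring with 2 hetero atoms, one six-membered aromatic ring with 1 hetero atom), on a saturated chain carbon bound to an oxygen on an aromatic ring. Going by the values given here, no pair of measured compounds differs in one place only, so the data offer no direct measure of this exchange. The nearest guide is compound 1, which already carries the entering group and gives 5.8 h, a value within the scatter of compound 3. Compound 1 also differs from compound 4 elsewhere, so this guide is only partial. In this assay, the expected step is a 1.1-fold higher number from compound 3 to compound 4 (0.05 log units; within the scatter), an estimate that stays within the scatter. The estimated half-life for compound 4 is 5.2 h, with an expected range of 3 h to 9 h.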

Compound 4, half-life: 1.9 h
Estimate against measurement, compound 4: 2.7-fold (0.44 log units) above, and the stated range ends above it.
By their numbers in this assay, from the lowest: compound 4; then compounds 3, 1 and 2 (each within the scatter of the next, the first and the last beyond it).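

Going by these compounds alone, compound 4 gives the first two single-place comparisons in this assay, and both point the same way. On a saturated chain carbon bound to an oxygen on an aromatic ring, the group of 6 carbon, 3 nitrogen and 1 oxygen in place of the group of 6 carbon and 4 nitrogen gives a 2.4-fold lower number from compound 3 to compound 4 (0.38 log units; beyond the scatter), so this position is not indifferent to the exchange, even though the two ring groups have the same ring types and heavy-atom count. Fluoro in place of hydrogen on an aromatic carbon gives a 3.1-fold lower number from compound 1 to compound 4 (0.48 log units; beyond the scatter), a modest step beyond the scatter, and the data offer no measured explanation for either step.

From the compounds shown here alone, each change has been read only once, so it remains open whether the same exchange would give a step of similar size without the fluoro, or whether fluoro would do the same alongside the group of 6 carbon and 4 nitrogen. Also open, going by these compounds, is how a methyl or a methoxy group on that aromatic carbon would compare with fluoro and hydrogen in this measure.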